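The source may report more compounds than this note shows. Statements on the series, on what has been measured and on what is new or still open speak of the compounds shown alone.

Measured so far in a functional assay on HCT-116 cells (Homo sapiens) for inhibition, with a stated time of 72 h; a lower number here means a stronger inhibitor, a higher number a weaker inhibitor:
Compound 1 `O=S(=O)(Nc1cccc2c(Cl)c[nH]c12)c1cccnc1`: 260 nM
Compound 2 `N#Cc1c[nH]c2c(NS(=O)(=O)c3cccnc3)cccc12`: 230 nM
Compound 3 `Cc1cncc(S(=O)(=O)Nc2cccc3c(Cl)c[nH]c23)c1`: 220 nM

Compound 3, at 220 nM, stands level with the other two, as all three values lie within the scatter of one another. Compound 4 `Cc1cncc(S(=O)(=O)Nc2cccc3c(C#N)c[nH]c23)c1` carries cyano in place of chloro on an aromatic carbon of compound 3: cyano in place of chloro on an aromatic carbon. The same exchange was measured once, a 1.1-fold lower number from compound 1 to compound 2 (0.05 log units; within the scatter), and stayed within the scatter. The methyl in place of hydrogen that separates the two pairs, a 1.2-fold lower number from compound 1 to compound 3 (0.07 log units; within the scatter), also stayed within it. No change beyond the scatter is therefore expected in this assay, and the estimated step is a 1.1-fold lower number from compound 3 to compound 4 (0.04 log units; within the scatter). Compound 4 is expected at 200 nM, with an estimated range of 100 nM to 400 nM.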

Compound 4, half-maximal inhibitory concentration: 190 nM
Compound 4: middle estimate off by 1.1-fold (0.02 log units), on the high side, within the range that was stated.
By their numbers in this assay, from the lowest: compounds 4, 3, 2 and 1 (each within the scatter of the next).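

In this assay, as far as these compounds go, cyano in place of chloro on an aromatic carbon gives a 1.2-fold lower number from compound 3 to compound 4 (0.06 log units; within the scatter), so this exchange at this position now has a reading on a second core, one that carries the methyl, and the two readings agree: the same change on two cores in this assay, a 1.1-fold lower number (0.05 log units; within the scatter) from compound 1 to compound 2 and a 1.2-fold lower number (0.06 log units; within the scatter) from compound 3 to compound 4, 1.0-fold (0.01 log units) apart, within the scatter of two such steps Methyl in place of hydrogen on an aromatic carbon, read with cyano present, gives a 1.2-fold lower number from compound 2 to compound 4 (0.08 log units; within the scatter), and this change also repeats across the two cores: the same change on two cores in this assay, a 1.2-fold lower number (0.07 log units; within the scatter) from compound 1 to compound 3 and a 1.2-fold lower number (0.08 log units; within the scatter) from compound 2 to compound 4, 1.0-fold (0.01 log units) apart, within the scatter of two such steps Whether an amine or a carboxylic acid at this position would move the number beyond the scatter remains open.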